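The source may report more compounds than this note shows. Statements on the series, on what has been measured and on what is new or still open speak of the compounds shown alone.

Measured so far:
compound 1, `COc1cc(/C=C/c2cc(/C=C/c3cc(OC)c(OC)c(OC)c3)nc(OCCCCBr)n2)cc(OC)c1OC`: > 20000 nM
compound 2, `COc1ccc(/C=C/c2cc(/C=C/c3ccc(OC)cc3)nc(OCCCCBr)n2)cc1`: > 20000 nM

In a functional assay on HCT-116 cells (Homo sapiens) for cytotoxicity, read by fluorescence and resazurin assay, with a stated time of 48 h (a lower number here means a stronger inhibitor, a higher number a weaker inhibitor), compound 1 gives > 20000 nM, which is a limit of the assay rather than a number. Compound 2 gives > 20000 nM, also a limit. Compound 1 thus stands where both shown values stand, (the limit of > 20000 nM in this assay, at which 2 of the 2 values shown sit). Compound 3 `COc1cc(/C=C/c2cc(/C=C/c3cc(OC)c(OC)c(OC)c3)nc(OCCCCCBr)n2)cc(OC)c1OC` differs from compound 1 by bromomethyl in place of bromo on a saturated chain carbon, four bonds along the chain from an oxygen on an aromatic ring. No measured step of this kind is shown, so no shift beyond the usual scatter is expected from compound 1 to compound 3 in this assay. Compound 3 is therefore estimated at 30000 nM, in the range 12000 nM to 80000 nM, the expected step being a step that the limit leaves unreadable from compound 1 to compound 3.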

Compound 3, half-maximal inhibitory concentration: > 20000 nM
Compound 3: no number, only a limit (the forecaster's own chance of this, stated with the estimate: 75%); the middle value does not contradict the limit.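

Going by these compounds alone, compound 1 and compound 3 each give only a limit rather than a number, so no step between them can be read. Whether the compounds shown differ at all in this assay stays open, since all share one limit: the limit of > 20000 nM in this assay, at which 3 of the 3 values shown sit.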